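A few compounds are considered here, and "the series" means these few. Any claim that something is new, unique, unknown or untested is made for them only; others in the source may bear on it.

In a functional assay on the whole organism for inhibition of sodium-dependent dopamine transporter (Mus musculus) (on this read-out lower numbers stand for an effect already at smaller amounts and higher numbers for an effect only at larger amounts of compound), compound 1 `Cc1ccc(C2CN(C)Cc3c(N)cccc32)cc1` gives about 22 mg/kg. Compound 2 `CCNC(=O)Nc1cccc2c1CN(C)CC2c1ccccc1` carries a different group on the shared core and an unsubstituted aryl ring. In this assay compound 2 reaches only the limit of the measurement and gives > 80 mg/kg. Within the data shown here, compound 2 therefore stands at the limit of > 80 mg/kg in this assay, at which 1 of the 2 values shown sits, whereas compound 1 stands at a numbered value, and no measured pair in this set differs in only one place. Compound 3 `CCCCNC(=O)Nc1cccc2c1CN(C)CC2c1ccccc1` differs from compound 2 by ethyl in place of hydrogen on a saturated chain carbon, two bonds along the chain from an amide-type nitrogen. Among the measured compounds shown here, since no step between measured compounds is available, the size of the change cannot be read from a comparison of numbers. In this assay the estimated step is a number no higher from compound 2 to compound 3 (the limit leaves the size open), which means no change beyond the usual scatter is expected. Compound 3 is expected to give about 80 mg/kg, within a range from 30 mg/kg to 200 mg/kg, and a further limit rather than a number is considered likely.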

Compound 3, dose for half-maximal effect: 69 mg/kg
Compound 3: the middle estimate sits 1.2-fold (0.06 log units) above what was measured, and the stated range covers the measured number.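

Butylamino in place of ethylamino gives the first comparison in this set between compounds that differ in one place, and in this assay the change reads as an at least 1.1-fold lower number from compound 2 to compound 3 (0.06 log units; that floor lies within the scatter). Compound 2 stands at a limit and not at a number: the limit of > 80 mg/kg in this assay, at which 1 of the 3 values shown sits.

On these data alone, compound 3 gives a number, 69 mg/kg, so the added ethyl on the saturated chain carbon brings this side chain into the measurable range, although the true size of the step stays unknown.

As far as these compounds go, it remains open how a longer chain such as hexyl, or a chain ending in an amine or a carboxylic acid, would read at this place. Also open, from the compounds shown here alone, is how butylamino would read on the core of compound 1, where compound 1 itself gives about 22 mg/kg.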